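This account rests on a few compounds, and the source may have more. Where it says the series, first, only, none or still open, it means among the compounds named here.

Measured in a functional assay on MCF7 cells (Homo sapiens) for antiproliferative activity, read by MTT assay, with a stated time of 24 h; on this read-out higher numbers stand for weaker inhibition and lower numbers for stronger inhibition:
- compound 1 `COC(=O)c1scc(-c2ccc(NC(=O)c3ccc(C(F)(F)F)cc3Br)cc2)c1OC`: 22400 nM
- compound 2 `COC(=O)c1scc(-c2ccc(NC(=O)c3cccc(I)c3)cc2)c1OC`: 12300 nM
- compound 3 `COC(=O)c1scc(-c2ccc(NC(=O)c3cc(I)ccc3F)cc2)c1OC`: 22500 nM

Compound 3, at 22500 nM, lies within the scatter of both other compounds in this assay. In compound 4 `COC(=O)c1scc(-c2ccc(NC(=O)c3ccc(C(F)(F)F)cc3)cc2)c1OC` the change is 4-(trifluoromethyl)phenyl in place of 2-fluoro-5-iodophenyl on a carbonyl carbon, on a carbonyl carbon. Going by the values given here, no measured step covers this exchange. Among the compounds with values here, the one measured step, a 1.8-fold higher number from compound 2 to compound 3 (0.26 log units; within the scatter), came with fluoro in place of hydrogen on an aromatic carbon and stayed within the scatter. Compound 1, which also carries a trifluoromethyl group, gives 22400 nM. No change beyond the scatter is therefore expected, and the estimated step is a 1.3-fold lower number from compound 3 to compound 4 (0.10 log units; within the scatter). For compound 4 the expected value is 18000 nM, with an estimated range of 9000 nM to 40000 nM.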

Compound 4, half-maximal inhibitory concentration: 24600 nM
Compound 4: middle estimate off by 1.4-fold (0.14 log units), on the low side; the range from low to high includes it.
By their numbers in this assay, from the lowest: compounds 2, 1, 3 and 4 (each within the scatter of the next).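

In this assay the exchange to 4-(trifluoromethyl)phenyl on the carbonyl carbon gave a 1.1-fold higher number from compound 3 to compound 4 (0.04 log units; within the scatter) and, from the 3-iodophenyl group, a 2.0-fold higher number from compound 2 to compound 4 (0.30 log units; within the scatter) so both steps stay within the scatter and this position does not separate these aryl groups. Hydrogen in place of bromo gave a 1.1-fold higher number from compound 1 to compound 4 (0.04 log units; within the scatter) and also stayed within the scatter. No evidence at hand bears on these results.

On these data alone, whether an amine or a carboxylic acid on this phenyl ring would move the number beyond the scatter stays open. The same holds for a saturated ring on the carbonyl carbon.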